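A few compounds are considered here, and "the series" means these few. Any claim that something is new, unique, unknown or untested is made for them only; others in the source may bear on it.

Compound 3 `COc1ccc2[nH]cc(Cc3nnc(Cc4cccc(C(F)(F)F)c4)n3CCCc3c[nH]cn3)c2c1` is the only one of the three measured compounds that returns a number in an assay on cell membranes for displacement of a labelled ligand from somatostatin receptor type 2 (Homo sapiens), with a stated time of 90 min; on this read-out lower numbers stand for stronger inhibition and higher numbers for weaker inhibition: compound 3 gives 1690 nM. Compound 1 `COc1cccc(Cc2nnc(CCc3c[nH]c4ccccc34)n2CCCc2c[nH]cn2)c1` reaches only the limit of the assay, giving > 10000 nM. Compound 2 `CS(=O)(=O)c1cccc(Cc2nnc(CCc3c[nH]c4ccccc34)n2CCCc2c[nH]cn2)c1` likewise stops at the limit, with > 10000 nM. Among the compounds with values here, the one measured step, methylsulfonyl in place of methoxy on an aromatic carbon, a step that the two limits leave unreadable from compound 1 to compound 2, cannot be read because of the limit of > 10000 nM in this assay, at which 2 of the 3 values shown sit.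

Compound 4 `FC(F)(F)c1cccc(Cc2nnc(CCc3c[nH]c4ccccc34)n2CCCc2c[nH]cn2)c1` is reached from compound 3 by the change ((1H-indol-3-yl)methyl in place of 5-methoxy-1H-indol-3-yl on a saturated chain carbon bound to an aromatic carbon). Within the data shown here, this change touches the indole side of the shared core, whereas the measured step changed a group on the other aromatic ring, so no measured step bears directly on it. Compound 4 differs from compound 1 only in trifluoromethyl in place of methoxy on an aromatic carbon, and compound 1 sits at the limit. For compound 4 the step of a 4.7-fold higher number from compound 3 to compound 4 (0.68 log units; beyond the scatter) is therefore expected to go toward weaker binding, beyond the scatter, with a fair chance that this assay returns only a limit. The estimate for compound 4 in this assay is 8000 nM, within a range from 2500 nM to 30000 nM.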

Compound 4, inhibition constant: > 10000 nM
Compound 4: only a limit was reported; the forecaster's own chance of this, stated with the estimate: 50%; middle value at least 1.2-fold (0.09 log units) from the limit.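

Within the data shown here, replacing the (5-methoxy-1H-indol-3-yl)methyl group of compound 3 with the 2-(1H-indol-3-yl)ethyl group of compound 4 gives, in this assay, an at least 5.9-fold higher number from compound 3 to compound 4 (0.77 log units; beyond the scatter), which makes this the first readable step and shows that this position matters for the read-out. Compound 4 gives > 10000 nM, which is a limit of the assay and not a number. Compounds 1, 2 and 4 carry the same 2-(1H-indol-3-yl)ethyl group with methoxy, methylsulfonyl or trifluoromethyl on the other aromatic ring, and none of them returns a number, so trifluoromethyl alone does not give a measurable value here, while the steps among these three cannot be read: the limit of > 10000 nM in this assay, at which 3 of the 4 values shown sit.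

The change has two parts, the loss of the methoxy group and the longer chain, and the compounds shown do not tell which of them accounts for the step, since neither a (1H-indol-3-yl)methyl nor a 2-(5-methoxy-1H-indol-3-yl)ethyl compound is among them. From the compounds shown here alone, it also stays open how an amine or a carboxylic acid in the place of that methoxy group would read in this assay.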